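A few compounds are considered here, and "the series" means these few. Any claim that something is new, unique, unknown or untested is made for them only; others in the source may bear on it.

Series notes. Compound 1 `OC[C@H]1O[C@@H](n2cc(F)c3c(-c4ccco4)ncnc32)[C@H](O)[C@@H]1O` serves as the reference: in a functional assay on HL-60 cells (Homo sapiens) for cytotoxicity, read by XTT assay, with a stated time of 3 days (a higher number here means a weaker inhibitor, a lower number a stronger inhibitor), compound 1 gives 1200 nM. Compound 2 `OC[C@H]1O[C@@H](n2cc(F)c3c(-c4cccs4)ncnc32)[C@H](O)[C@@H]1O` differs from compound 1 by thiophen-2-yl in place of furan-2-yl on an aromatic carbon and in this assay compound 2 gives 4300 nM, so the change gave a 3.6-fold higher number from compound 1 to compound 2 (0.55 log units; beyond the scatter). Compound 3 `OC[C@H]1O[C@@H](n2cc(Cl)c3c(-c4ccco4)ncnc32)[C@H](O)[C@@H]1O` differs from compound 1 by chloro in place of fluoro on an aromatic carbon; in this assay compound 3 gives 21600 nM, a step of an 18-fold higher number from compound 1 to compound 3 (1.26 log units; beyond the scatter). Within the data shown here, compound 3 thus stands highest of the three numbers so far.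

Compound 4 `OC[C@H]1O[C@@H](n2cc(Cl)c3c(-c4cccs4)ncnc32)[C@H](O)[C@@H]1O` is not yet measured. It differs from compound 3 by thiophen-2-yl in place of furan-2-yl on an aromatic carbon, the same change as that from compound 1 to compound 2, made on the core of compound 3 rather than that of compound 1; the surroundings of the place are described identically in both cases. Among the measured compounds shown here, for compound 4 in this assay the step from compound 3 is expected to resemble the earlier one, giving a 3.0-fold higher number from compound 3 to compound 4 (0.48 log units; beyond the scatter), resting on the earlier 3.6-fold higher number from compound 1 to compound 2 (0.55 log units; beyond the scatter) seen on the core of compound 1, with wider uncertainty because only one such pair exists. Compound 4 is therefore estimated at 65000 nM in this assay, within 20000 nM to 200000 nM.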

Compound 4, half-maximal inhibitory concentration: 5500 nM
The estimate for compound 4 lay 12-fold (1.07 log units) above the measured number; measured number outside the range, below it.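

In this assay, thiophen-2-yl in place of furan-2-yl does not carry over from the core of compound 1 to the core of compound 3, where the change gives a 3.9-fold lower number from compound 3 to compound 4 (0.59 log units; beyond the scatter) and so reverses direction: the same change on two cores in this assay, a 3.6-fold higher number (0.55 log units; beyond the scatter) from compound 1 to compound 2 and a 3.9-fold lower number (0.59 log units; beyond the scatter) from compound 3 to compound 4, 14-fold (1.15 log units) apart, beyond the scatter of two such steps

Chloro in place of fluoro also depends on its surroundings, giving a 1.3-fold higher number from compound 2 to compound 4 (0.11 log units; within the scatter) when thiophen-2-yl is present, against a far larger step when furan-2-yl is present: the same change on two cores in this assay, an 18-fold higher number (1.26 log units; beyond the scatter) from compound 1 to compound 3 and a 1.3-fold higher number (0.11 log units; within the scatter) from compound 2 to compound 4, 14-fold (1.15 log units) apart, beyond the scatter of two such steps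

Among these compounds, these four compounds show that the two changes do not combine independently, but they form only one set of paired changes, so they show neither why this happens nor how either change would behave on another core.

Going by these compounds, it remains open whether this dependence extends to other groups at the same two places, such as bromo or methyl in place of the fluoro or chloro. The same question applies to an amine or a phenyl ring in place of the furan-2-yl or thiophen-2-yl.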